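Bromo to methyl in a small antiproliferative series

The source may hold more compounds than are shown below. What is called first, only, known or untested is meant among the compounds shown, and "the series" means these compounds.

In a functional assay on MCF7 cells (Homo sapiens) for antiproliferative activity, read by MTT assay, with a stated time of 48 h (on this read-out lower numbers stand for stronger inhibition and higher numbers for weaker inhibition), compound 1 (`O=C(/C=C/c1ccc(Cl)cc1)Nc1cc(-c2ccccc2)[nH]n1`) gives 970 nM, compound 2 (`O=C(/C=C/c1ccc([N+](=O)[O-])cc1)Nc1cc(-c2ccccc2)[nH]n1`) gives 630 nM and compound 3 (`O=C(/C=C/c1ccc(Br)cc1)Nc1cc(-c2ccccc2)[nH]n1`) gives 1240 nM. Compound 3 thus stands within the scatter of both other compounds, with measured steps of a 1.3-fold higher number from compound 1 to compound 3 (0.11 log units; within the scatter) and a 2.0-fold higher number from compound 2 to compound 3 (0.29 log units; within the scatter). Compound 4 (`Cc1ccc(/C=C/C(=O)Nc2cc(-c3ccccc3)[nH]n2)cc1`) has not yet been measured. Its difference from compound 3 is methyl in place of bromo on an aromatic carbon. Within the data shown here, no measured compound carries that methyl, so the only guides are the exchanges at the same place, which also include a 1.5-fold lower number from compound 1 to compound 2 (0.19 log units; within the scatter). All three steps stay within the scatter, although three compounds make a narrow basis. No step beyond the scatter is therefore expected in this assay, and no direction can be favoured with confidence. The estimate amounts to an expected 1.2-fold lower number from compound 3 to compound 4 (0.09 log units; within the scatter). For compound 4 the expected value is 1000 nM, with an estimated range from 500 nM to 2100 nM.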

Compound 4, half-maximal inhibitory concentration: 1780 nM
Beside the measured number, compound 4's estimate is 1.8-fold (0.25 log units) below it; measured number inside the range.
By their numbers in this assay, from the lowest: compounds 2, 1, 3 and 4 (each within the scatter of the next, the first and the last beyond it).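

In this assay, the methyl group gives a 1.4-fold higher number from compound 3 to compound 4 (0.16 log units; within the scatter) and a 1.8-fold higher number from compound 1 to compound 4 (0.26 log units; within the scatter), so replacing either bromo or chloro with methyl at this position stays within the scatter. The remaining comparison gives a 2.8-fold higher number from compound 2 to compound 4 (0.45 log units; beyond the scatter), a modest change and the only step among these four compounds that lies beyond the scatter, showing that the choice of group at this position can register in this assay, at least between nitro and methyl. No measured evidence accounts for that gap.

On these data alone, it remains open whether an amine, a carboxylic acid or a longer chain at this position would extend the spread seen here or fall within it. It is also unknown whether the exchange of nitro for methyl would give a similar step elsewhere on the shared core.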